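A few compounds are considered here, and "the series" means these few. Any claim that something is new, unique, unknown or untested is made for them only; others in the source may bear on it.

Measured so far in a functional assay on NCI-H1975 cells (Homo sapiens) for antiproliferative activity, read by MTT assay, with a stated time of 72 h; on this read-out higher numbers stand for weaker inhibition and lower numbers for stronger inhibition:
Compound 1 `C=CC(=O)Nc1cc2c(Nc3ccc(OCc4cccc(F)c4)c(Cl)c3)ncnc2cc1OCc1cn(CCCC(=O)NO)nn1` gives 12000 nM
Compound 2 `C=CC(=O)Nc1cc2c(Nc3ccc(OCc4cccc(F)c4)c(Cl)c3)ncnc2cc1OCc1cn(CCCCC(=O)NO)nn1` gives 14500 nM

Among the compounds with values here, the only measured step is a 1.2-fold higher number from compound 1 to compound 2 (0.08 log units; within the scatter) and leaves compound 2 level with compound 1. Compound 3 `C=CC(=O)Nc1cc2c(Nc3ccc(F)c(Cl)c3)ncnc2cc1OCc1cn(CCCCC(=O)NO)nn1` keeps the chain of compound 2 and differs elsewhere, by fluoro in place of (3-fluorobenzyl)oxy on an aromatic carbon. The measured step concerned only that chain, so it sets no size for this exchange, and nothing measured fixes a direction. With so much leaving, a step beyond the scatter in this assay is still expected, tentatively toward a lower number. The expected change is a 2.4-fold lower number from compound 2 to compound 3 (0.38 log units; beyond the scatter). For compound 3 the estimated value is 6000 nM, with an expected range from 1500 nM to 20000 nM.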

Compound 3, half-maximal inhibitory concentration: 2500 nM
Beside the measured number, compound 3's estimate is 2.4-fold (0.38 log units) above it; low and high end bracket the measured number.
By their numbers in this assay, from the lowest: compound 3; then compounds 1 and 2 (each within the scatter of the next).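

Exchanging (3-fluorobenzyl)oxy for fluoro on this aromatic carbon gives in this assay a 5.8-fold lower number from compound 2 to compound 3 (0.76 log units; beyond the scatter) and so shows that the large group with its aromatic ring is not needed for activity here. Unlike the chain step, this change lies beyond the scatter, so this position affects the read-out where the chain step did not. No measured evidence explains this step.

On these data alone, whether the step follows from losing the benzyl ring or from the fluoro itself remains open, and a hydrogen, chloro or methoxy group on this carbon would help separate the two. As far as these compounds go, whether the shorter chain of compound 1 behaves alike with fluoro also remains open.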